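Working notes on compounds 1 to 3 of the series

This account rests on a few compounds, and the source may have more. Where it says the series, first, only, none or still open, it means among the compounds named here.

Measured compounds:
Compound 1, `Cc1ccc(-c2cn(C/C=C3\OC(=O)C(OCc4ccccc4)=C3OCc3ccccc3)nn2)cc1` — > 100000 nM (limit)
Compound 2, `CCCCCc1ccc(-c2cn(C/C=C3\OC(=O)C(OCc4ccccc4)=C3OCc3ccccc3)nn2)cc1` — > 100000 nM (limit)

In a functional assay on MCF7 cells (Homo sapiens) for antiproliferative activity, read by MTT assay, with a stated time of 72 h (on this read-out lower numbers stand for stronger inhibition and higher numbers for weaker inhibition), compound 1 gives > 100000 nM, which is a limit of the assay and not a number. In this assay compound 2 gives > 100000 nM, again a limit. The step that the two limits leave unreadable from compound 1 to compound 2 is therefore unreadable, both ends sitting at the limit of > 100000 nM in this assay, at which 2 of the 2 values shown sit. Compound 2 thus stands at the limit of this assay, with no measured number beside it that could place it higher or lower than compound 1.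

Compound 3, `COc1ccc(-c2cn(C/C=C3\OC(=O)C(OCc4ccccc4)=C3OCc3ccccc3)nn2)cc1`, is not yet measured. Relative to compound 2 it shows (methoxy in place of pentyl on an aromatic carbon). Among the measured compounds shown here, no measured step bears on this change: the single step available cannot be read for size or direction, and no compound in the set has a number. The expectation for compound 3 in this assay rests on compound 2 alone, because compound 2 sits at the limit of > 100000 nM in this assay, at which 2 of the 2 values shown sit, and the change on the aryl group is small in count. The step of a number no higher from compound 2 to compound 3 (the limit leaves the size open) is expected to be none beyond the scatter, with a real chance that only a limit is again returned. Compound 3 is expected at 100000 nM, within 30000 nM to 300000 nM.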

Compound 3, half-maximal inhibitory concentration: 39100 nM
For compound 3 the middle estimate is 2.6-fold (0.41 log units) above the measured one; measured number inside the range.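

In this assay, among the compounds shown here, compound 3 is the first compound of the series to return a number and not a limit, which shows that the aromatic carbon para to a large group can change the read-out, and that the change can be made with a small group. Methoxy in place of pentyl gives an at least 2.5-fold lower number from compound 2 to compound 3 (0.40 log units; beyond the scatter), and methoxy in place of methyl gives an at least 2.5-fold lower number from compound 1 to compound 3 (0.40 log units; beyond the scatter); both sizes are lower bounds, and the two steps agree in direction whichever alkyl group leaves. The step between the two alkyl compounds cannot be read, so methyl and pentyl remain unordered, each of compound 1 and compound 2 standing at a limit of the assay: the limit of > 100000 nM in this assay, at which 2 of the 3 values shown sit.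

The compounds shown leave open whether the gain belongs to methoxy in particular or would also appear with a hydroxyl, an amine or a longer alkoxy chain at the same place. They also leave open whether changes on the shared core, such as replacing a benzyl ether, would move the number further from that of compound 3.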